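A few compounds are considered here, and "the series" means these few. Any claim that something is new, unique, unknown or untested is made for them only; others in the source may bear on it.

Compound 1 `C=C(Br)C(=O)Nc1cccc(-c2cn3nc(Cc4ccccc4)sc3n2)c1`: 4500 nM
Compound 2 `C=C(Br)C(=O)Nc1cccc(-c2cn3nc(-c4ccc(C)cc4)sc3n2)c1`: 2000 nM

In a functional assay on HeLa cells (Homo sapiens) for inhibition, read by cell counting, with a stated time of 4 days (on this read-out higher numbers stand for weaker inhibition and lower numbers for stronger inhibition), compound 2 gives 2000 nM, the lowest of the two numbers; its nearest neighbour is compound 1, at 4500 nM. Compound 3 `C=C(Br)C(=O)Nc1cccc(-c2cn3nc(-c4ccc(OC)c(OC)c4)sc3n2)c1` is the next step: 3,4-dimethoxyphenyl in place of 4-methylphenyl on an aromatic carbon. For the measured compounds named here, the one measured step that bears on this position, a 2.3-fold lower number from compound 1 to compound 2 (0.35 log units; beyond the scatter), was modest and came from exchanging a benzyl for a 4-methylphenyl; here the aryl ring stays and only its substituents change. For compound 3 no step beyond the scatter is therefore expected, no change at the digits printed from compound 2 to compound 3 (within the scatter), and compound 3 is estimated at 2000 nM, within 700 nM to 6000 nM.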

Compound 3, half-maximal inhibitory concentration: 610 nM
Compound 3: the middle estimate sits 3.3-fold (0.52 log units) above what was measured; the measured number lies below the stated range.
By their numbers in this assay, from the lowest: compound 3; then compound 2; then compound 1.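

In this assay, the substituents on the aryl ring at this position prove to matter on their own: with the ring kept, 3,4-dimethoxyphenyl in place of 4-methylphenyl gives a 3.3-fold lower number from compound 2 to compound 3 (0.52 log units; beyond the scatter). Measured against benzyl, the same group gives a 7.4-fold lower number from compound 1 to compound 3 (0.87 log units; beyond the scatter), a larger step than that seen with 4-methylphenyl. No measurement at hand accounts for these steps. The compounds shown leave open whether a single methoxy group would give the same number as the pair. They also leave open how an amine or a carboxylic acid on this phenyl ring would read.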